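Bromo for fluoro on a butyl-substituted sulfonate ester

This account rests on a few compounds, and the source may have more. Where it says the series, first, only, none or still open, it means among the compounds named here.

Measured compounds:
compound 1 `CN1CCN(c2ccc(S(=O)(=O)Oc3cccc(F)c3)cc2)C1=O`: > 100000 nM
compound 2 `CN1CCN(c2ccc(S(=O)(=O)Oc3cccc(Br)c3)cc2)C1=O`: 1500 nM
compound 3 `CCCCN1CCN(c2ccc(S(=O)(=O)Oc3cccc(F)c3)cc2)C1=O`: 310 nM

Compound 4 `CCCCN1CCN(c2ccc(S(=O)(=O)Oc3cccc(Br)c3)cc2)C1=O` has not yet been tested. In a functional assay on MCF7 cells (Homo sapiens) for antiproliferative activity, read by sulforhodamine B assay, with a stated time of 48 h (a higher number here means a weaker inhibitor, a lower number a stronger inhibitor), compound 1 gives only a limit, > 100000 nM. Compound 2 reaches 1500 nM, a change of an at least 66-fold lower number from compound 1 to compound 2 (1.82 log units; beyond the scatter), the structural difference being (bromo in place of fluoro on an aromatic carbon). Compound 3 reaches 310 nM, a change of an at least 320-fold lower number from compound 1 to compound 3 (2.50 log units; beyond the scatter), the difference being (propyl in place of hydrogen on a saturated chain carbon bound to an amide-type nitrogen in a ring); this is also how the core of compound 3 differs from the core of compound 1.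

Compound 4 carries the same change on the core of compound 3: bromo in place of fluoro on an aromatic carbon. Going by the values given here, because the earlier step rests on (the limit of > 100000 nM in this assay, at which 1 of the 3 values shown sits), its true size is unknown, and the step from compound 3 is expected to be smaller than the one observed from compound 1, a 4.4-fold lower number from compound 3 to compound 4 (0.65 log units; beyond the scatter). Compound 4 is therefore estimated at 70 nM in this assay.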

Compound 4, half-maximal inhibitory concentration: 85 nM
Beside the measured number, compound 4's estimate is 1.2-fold (0.08 log units) below it, within the range that was stated.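

In this assay, bromo in place of fluoro gives a 3.6-fold lower number from compound 3 to compound 4 (0.56 log units; beyond the scatter), so the change again lowers the number on the butyl core, but the step does not carry over at the same size from the core of compound 1: the same change on two cores in this assay, an at least 66-fold lower number (1.82 log units; beyond the scatter) from compound 1 to compound 2 and a 3.6-fold lower number (0.56 log units; beyond the scatter) from compound 3 to compound 4, at least 18-fold (1.26 log units) apart, beyond the scatter of two such steps. The butyl chain, read as propyl in place of hydrogen, likewise gives an 18-fold lower number from compound 2 to compound 4 (1.25 log units; beyond the scatter), and this step also differs in size from its counterpart on the other core: the same change on two cores in this assay, an at least 320-fold lower number (2.50 log units; beyond the scatter) from compound 1 to compound 3 and an 18-fold lower number (1.25 log units; beyond the scatter) from compound 2 to compound 4, at least 18-fold (1.26 log units) apart, beyond the scatter of two such steps. Going by these compounds, the direction of each change holds across the two cores, but the true size of the gaps remains unknown because compound 1 gives only a limit, > 100000 nM: the limit of > 100000 nM in this assay, at which 1 of the 4 values shown sits.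

The compounds shown carry only fluoro and bromo on the aromatic ring, which leaves open how chloro, iodo or methoxy would fare there. They also leave open whether a longer chain such as hexyl, or a chain ending in an amine, would lower the number further.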